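Swapping a pyrazole for trifluoromethyl: solubility expectation

A few compounds are considered here, and "the series" means these few. Any claim that something is new, unique, unknown or untested is made for them only; others in the source may bear on it.

Three compounds have a number in a physicochemical assay for solubility, read by HPLC, in phosphate buffer, at pH 6.5; on this read-out lower numbers stand for lower solubility and higher numbers for higher solubility:

Compound 1, `CNc1nc(NCCCN(C)C)c2sc(-c3ccc(-n4cccn4)cc3)cc2n1`, gives 191 ug/mL.
Compound 2, `CNc1nc(NCCCN(C)C)c2oc(-c3ccccc3)cc2n1`, gives 203 ug/mL.
Compound 3, `CNc1nc(NCCCN(C)C)c2cc(-c3ccccc3)sc2n1`, gives 184 ug/mL.

All three numbers lie within the scatter of one another, so none of the compounds can be called more or less soluble than the others; compound 1 sits with compound 3 and compound 2 in one tight group in this assay.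

Compound 4, `CNc1nc(NCCCN(C)C)c2sc(-c3ccc(C(F)(F)F)cc3)cc2n1`, has not yet been measured. It differs from compound 1 in one place: trifluoromethyl in place of 1H-pyrazol-1-yl on an aromatic carbon. The new group sits on an aromatic carbon of a six-membered aromatic ring of carbon only, para to a large group.

Among the measured compounds shown here, no measured pair shows a change of this kind, so the expectation rests on the value of compound 1 alone. In this assay a step downward is expected, of moderate size, beyond the scatter. Compound 4 is therefore estimated at 60 ug/mL, with a range from 20 ug/mL to 160 ug/mL, which corresponds to an expected step of a 3.2-fold lower number from compound 1 to compound 4 (0.50 log units; beyond the scatter).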

Compound 4, solubility: 177 ug/mL
Beside the measured number, compound 4's estimate is 3.0-fold (0.47 log units) below it; the measured number lies above the stated range.
By their numbers in this assay, from the lowest: compounds 4, 3, 1 and 2 (each within the scatter of the next).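

In this assay, replacing 1H-pyrazol-1-yl with trifluoromethyl on this aromatic carbon, para to a large group, gives a 1.1-fold lower number from compound 1 to compound 4 (0.03 log units; within the scatter), so the read-out does not separate the two groups at this position. They differ in what is counted on them: 1H-pyrazol-1-yl brings a five-membered aromatic ring and hydrogen-bond acceptors, while trifluoromethyl brings no ring and no hydrogen-bond acceptors, yet compound 4 joins the same tight group as compound 1. Nothing measured here explains this result.

Going by these compounds, it remains open whether an amine or a carboxylic acid on this same aromatic carbon would carry the number beyond the scatter. Among the compounds shown here, this is also the only pair with this exchange, so whether it would read the same way on a different core is unknown.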